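Acetamido for methylsulfonyl on the benzyl group of compound 1

This account rests on a few compounds, and the source may have more. Where it says the series, first, only, none or still open, it means among the compounds named here.

Compound 1 `CN(Cc1ccc(S(C)(=O)=O)cc1)C1CCN(CCCc2c[nH]c3ccc(-n4cnnc4)cc23)CC1` gives 18 nM in an assay on CHO cells for displacement of a labelled ligand from 5-hydroxytryptamine receptor 1D (Homo sapiens) (on this read-out higher numbers stand for weaker inhibition and lower numbers for stronger inhibition), the highest of the three numbers shown. Compound 2 `C[C@@H](NCC1CCN(CCCc2c[nH]c3ccc(-n4cnnc4)cc23)CC1)c1ccccc1` gives 1.4 nM and compound 3 `CC(=O)Nc1ccc([C@@H](C)NCC2CCN(CCCc3c[nH]c4ccc(-n5cnnc5)cc34)CC2)cc1` gives 1.5 nM; both stand beyond the scatter from compound 1, but they carry a different amine arrangement on the shared core. Compound 4 `CC(=O)Nc1ccc(CN(C)C2CCN(CCCc3c[nH]c4ccc(-n5cnnc5)cc34)CC2)cc1` differs from compound 1 by acetamido in place of methylsulfonyl on an aromatic carbon. For the measured compounds named here, the only step that touches the acetamido group is a 1.1-fold higher number from compound 2 to compound 3 (0.03 log units; within the scatter), which shows that adding acetamido to an otherwise bare ring changes nothing. Going by the values given here, no step measures the loss of methylsulfonyl. The step from compound 1 to compound 4 is therefore expected to be small, a 1.3-fold lower number from compound 1 to compound 4 (0.11 log units; within the scatter), with no direction settled. Compound 4 is estimated at 14 nM, within 5 nM to 40 nM.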

Compound 4, half-maximal inhibitory concentration: 19 nM
Beside the measured number, compound 4's estimate is 1.4-fold (0.13 log units) below it; the measured number falls inside the stated range.
By their numbers in this assay, from the lowest: compounds 2 and 3 (each within the scatter of the next); then compounds 1 and 4 (each within the scatter of the next).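

In this assay, putting acetamido in place of methylsulfonyl on the aromatic carbon para to a large group gives a 1.1-fold higher number from compound 1 to compound 4 (0.02 log units; within the scatter). Acetamido had so far been compared only with hydrogen, on a different amine arrangement; this is its first direct comparison with methylsulfonyl, and a hydrogen-bond donor enters the position with no readable change. No measurement bearing on the reason is available.

Open, on these data alone, is how a carboxylic acid, an amine or a longer chain at this position would read. Also open, as far as these compounds go, is how the bare ring would read on this amine arrangement.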